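Trimming the propargyl ether of a benzophenone imidazole

The source may hold more compounds than are shown below. What is called first, only, known or untested is meant among the compounds shown, and "the series" means these compounds.

The shared core is a benzophenone carrying an imidazolylmethyl group, and the set so far holds two measured members. Compound 1 `C#CCOc1ccc(C(=O)c2cccc(Cn3ccnc3)c2)cc1` gives 650 nM in an assay on isolated protein for inhibition of Aromatase (Homo sapiens), read by fluorescence, with stated times of 10 min and 60 min (on this read-out higher numbers stand for weaker inhibition and lower numbers for stronger inhibition), the lowest of the two numbers recorded. Compound 2 `CCC#CCOc1ccc(C(=O)c2ccc(Cn3ccnc3)cc2)cc1` gives 1430 nM in this assay, a higher number than compound 1. The step under consideration leads from compound 1 to compound 3 `O=C(c1ccc(O)cc1)c1cccc(Cn2ccnc2)c1`, which has not yet been measured in this assay; the change is hydrogen in place of propargyl on an oxygen on an aromatic ring, or, cut one bond further out, propargyloxy to hydroxy. Within the data shown here, no measured pair in this set shows this change, so its size cannot be read from the data. For compound 3 a weakening is expected, a step of a 4.6-fold higher number from compound 1 to compound 3 (0.66 log units; beyond the scatter). Compound 3 is estimated at 3000 nM, within a range of 800 nM to 12000 nM.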

Compound 3, half-maximal inhibitory concentration: 13 nM
For compound 3 the middle estimate is 230-fold (2.36 log units) above the measured one, outside the stated range (below it).
By their numbers in this assay, from the lowest: compound 3; then compound 1; then compound 2.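

In this assay, putting hydrogen in place of propargyl on an oxygen on an aromatic ring gives a 50-fold lower number from compound 1 to compound 3 (1.70 log units; beyond the scatter), a large gain in inhibition. Among these compounds, this is the first reading of this change in the set, and it shows that the propargyl group is not needed for inhibition at this position, since the hydroxy compound 3 inhibits far more strongly. No measurement shown here accounts for the size of this step.

The compounds shown leave open whether the gain belongs to the free hydroxy group itself or simply to the loss of propargyl, which a methyl ether or an acetate on the same oxygen would help separate. They also leave open whether propargyloxy to hydroxy gives a similar step on the core of compound 2.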